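Swapping an Aryl Group for an Aryl Ether on Compound 2

The source may report more compounds than this note shows. Statements on the series, on what has been measured and on what is new or still open speak of the compounds shown alone.

Of the compounds shown here, three sharing one core have been measured in an in vitro functional assay on 1321-N1 cells for agonist activity at Free fatty acid receptor 1 (Homo sapiens), read by fluorescence, spectrophotometry and calcium flux; a higher number here means that more compound is needed for the effect, a lower number that less compound is needed. Compound 1, `O=C(O)CCc1ccc(C#Cc2ccnc(F)c2)cc1`, gives 513 nM; compound 2, `Cc1ccccc1-c1cc(C#Cc2ccc(CCC(=O)O)cc2)ccn1`, gives 1070 nM; and compound 3, `O=C(O)CCc1ccc(C#Cc2cccnc2Cl)cc1`, gives 603 nM. Among these, compound 2 carries the highest number: its gap to compound 3 lies within the scatter, while its gap to compound 1 is larger, the step of a 2.1-fold higher number from compound 1 to compound 2 (0.32 log units; beyond the scatter) being the only single-point change recorded so far, where 2-methylphenyl replaced fluoro on an aromatic carbon.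

Compound 4, `O=C(O)CCc1ccc(C#Cc2ccnc(Oc3ccccc3)c2)cc1`, has not yet been measured. It differs from compound 2 in one place: phenoxy in place of 2-methylphenyl on an aromatic carbon. Among the measured compounds shown here, the only step that bears on this change is the one from compound 1 to compound 2, which was modest and went toward a higher number when a small substituent was exchanged for 2-methylphenyl. For the measured compounds named here, no measured pair contrasts an aryl group with an aryl ether at that carbon, so the data give no direction for the present exchange. The expected step of a 1.3-fold lower number from compound 2 to compound 4 (0.13 log units; within the scatter) is taken to be small, with room on either side. Compound 4 is therefore estimated at 800 nM in this assay, within a range from 300 nM to 2500 nM.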

Compound 4, half-maximal effective concentration: 479 nM
Compound 4: the middle estimate sits 1.7-fold (0.22 log units) above what was measured; measured number inside the range.
By their numbers in this assay, from the lowest: compounds 4, 1, 3 and 2 (each within the scatter of the next, the first and the last beyond it).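

In this assay the exchange of 2-methylphenyl for phenoxy, on the aromatic carbon next to the ring nitrogen, gives a 2.2-fold lower number from compound 2 to compound 4 (0.35 log units; beyond the scatter) and so offers the first contrast at this carbon between two groups that each carry a six-membered aromatic ring of carbon only. The earlier step had shown only a rise on going from fluoro to 2-methylphenyl, whereas a 1.1-fold lower number from compound 1 to compound 4 (0.03 log units; within the scatter) shows that an aromatic ring at this carbon does not always bring such a rise: with phenoxy in place, the number stays level with that of the fluoro compound, and compound 2 alone stands apart from compound 1 among these three groups. The data shown hold no evidence on why the two aromatic groups part in this way.

The exchange removes the methyl and inserts the oxygen in a single step, and the compounds shown cannot separate the two, which a plain phenyl group at this carbon would begin to do. Going by these compounds, it also remains open how an amine or a methylene link in place of the ether oxygen would compare, and whether a methyl on the phenoxy ring would move the number.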